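This account rests on a few compounds, and the source may have more. Where it says the series, first, only, none or still open, it means among the compounds named here.

In an assay on membranes from CHO cells for displacement of a labelled ligand from adenosine receptor A1 (Homo sapiens), read by scintillation counting, with a stated time of 60 min, tested at 1 uM (a lower number here means less inhibition, a higher number more inhibition at the concentration tested (going by the name of the read-out)), the three measured compounds gave:

Compound 1 `CCNC(=O)C1=C(C)NC(=O)NC1c1ccco1`: 2%
Compound 2 `CCNC(=O)C1=C(C)NC(=O)NC1c1ccoc1`: 1%
Compound 3 `CCNC(=O)C1=C(C)NC(=O)NC1c1ccsc1`: 3%

Compound 3 carries the highest of these three numbers, yet the steps leading to it, a number 1 percentage points higher from compound 1 to compound 3 (within the scatter) and a number 2 percentage points higher from compound 2 to compound 3 (within the scatter), both lie within the scatter, as does a number 1 percentage points lower from compound 1 to compound 2 (within the scatter). The three numbers therefore lie level with one another in this assay, and none of them can be said to be higher or lower than another.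

Compound 4 `CC1=C(C(=O)OC2CCCC2)C(c2ccsc2)NC(=O)N1` differs from compound 3 in one place: cyclopentyloxy in place of ethylamino on a carbonyl carbon. Each of the three measured steps changed only the aromatic ring on the saturated ring carbon, and each was too small to tell apart from noise. Among the compounds with values here, none of them touches the carbonyl carbon, so no measured step bears directly on the change from compound 3 to compound 4. With every measured compound showing almost no inhibition and nothing to suggest the carbonyl substituent moves the number, the expected step in this assay is none beyond the scatter, that is a number 1 percentage points higher from compound 3 to compound 4 (within the scatter) as an estimate. On that basis compound 4 is expected to give about 4% in this assay, with a likely range from -8% to 22%.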

Compound 4, a percentage reported as inhibition, at one concentration (the size of the read-out at that concentration, not a potency): 5%
The estimate for compound 4 lay 1 percentage points below the measured number; measured number inside the range.
By their numbers in this assay, from the lowest: compounds 2, 1, 3 and 4 (each within the scatter of the next).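

Within the data shown here, this is the first change at the carbonyl carbon rather than on the aromatic ring, and in this assay replacing ethylamino with cyclopentyloxy gives a number 2 percentage points higher from compound 3 to compound 4 (within the scatter). The swap is a substantial one on paper: ethylamino, with 3 heavy atoms and 1 hydrogen-bond donor, leaves, while cyclopentyloxy, with 6 heavy atoms, one five-membered non-aromatic ring of carbon only and 0 hydrogen-bond donors, enters, yet the two compounds remain level at the concentration tested. No separate measurement bears on why this larger change in the group leaves the number within the scatter.

The compounds shown leave open whether another group on this carbonyl carbon, such as a carboxylic acid, a cyclic amine or a longer chain, would move the number beyond the scatter. They also leave open whether cyclopentyloxy would give a similar reading alongside furan-2-yl or furan-3-yl on the saturated ring carbon, since here it appears only with thiophen-3-yl.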